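Boc-amine replacement for the diethylmethylpyrazole on the piperidine

The source may hold more compounds than are shown below. What is called first, only, known or untested is meant among the compounds shown, and "the series" means these compounds.

Compound 1 `CCc1nn(CC)c(C2CCN(C(=O)CN3CN(c4ccccc4)C4(CCN(C(=O)c5ccc(C6CCCCC6)cc5)CC4)C3=O)CC2)c1C` carries a 1,3-diethyl-4-methyl-1H-pyrazol-5-yl group on the piperidine of the glycinamide side chain; in an assay on HEK293 cells for displacement of a labelled ligand from NPC1-like intracellular cholesterol transporter 1 (Homo sapiens) (a lower number here means a stronger inhibitor, a higher number a weaker inhibitor), compound 1 gives "not determined" (no result reported), so it gives no anchor within the series. Two measured analogues share the spiro core. Compound 2 `CC(C)(C)OC(=O)NCCNC(=O)CN1CN(c2ccccc2)C2(CCN(C(=O)c3ccc(C4CCCCC4)cc3)CC2)C1=O` places a (tert-butoxycarbonyl)amino on an open ethylene linker and in this assay compound 2 gives 5500 nM. Compound 3 `CC(C)(C)c1ccc(C(=O)N2CCC3(CC2)C(=O)N(CC(=O)N2CCN(S(C)(=O)=O)CC2)CN3c2ccccc2)cc1` carries a methanesulfonylpiperazine amide together with a tert-butyl phenyl ketone and in this assay compound 3 gives 19000 nM. Both values sit in the weak micromolar region.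

Compound 4 `CC(C)(C)OC(=O)NC1CCN(C(=O)CN2CN(c3ccccc3)C3(CCN(C(=O)c4ccc(C5CCCCC5)cc4)CC3)C2=O)CC1` differs from compound 1 by one change: (tert-butoxycarbonyl)amino in place of 1,3-diethyl-4-methyl-1H-pyrazol-5-yl on a saturated ring carbon. With no number for compound 1, neither size nor direction of this step can be set against a measured starting point; it can only be placed beside compound 2, whose (tert-butoxycarbonyl)amino on an acyclic chain gives 5500 nM in this assay. Compound 4 is therefore expected to fall in the same weak range, with an estimated value of 5000 nM and a plausible range from 1500 nM to 20000 nM, wide given the single comparable point.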

Compound 4, half-maximal inhibitory concentration: 4800 nM
For compound 4 the middle estimate is 1.0-fold (0.02 log units) above the measured one; measured number inside the range.
By their numbers in this assay, from the lowest: compounds 4 and 2 (each within the scatter of the next); then compound 3.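

In this assay compound 4 gives 4800 nM while compound 1 gives "not determined" (no result reported) and so no step can be read between compound 1 and compound 4. The compounds shown leave open how 1,3-diethyl-4-methyl-1H-pyrazol-5-yl compares with (tert-butoxycarbonyl)amino on the saturated ring carbon. No supporting data bear on this result.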